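Adding an Ethoxyphenyl Ring to an Ester Benzamide

The source may report more compounds than this note shows. Statements on the series, on what has been measured and on what is new or still open speak of the compounds shown alone.

Of the compounds shown here, three have been tested in an ADME assay on Raji cells (Homo sapiens) for cytotoxicity, read by CellTiter-Glo and resazurin assay, with a stated time of 72 h (a lower number here means that less compound is needed, a higher number that more compound is needed for the effect), and every reading is a limit of the assay rather than a number.
Compound 1, `CC(C)N(Cc1cccc(OCCCCCC(=O)O)c1)C(=O)c1ccccc1`, gives > 26000 nM.
Compound 2, `COc1ccc(F)c(-c2ccc(C(=O)N(Cc3cccc(OCCCCCC(=O)O)c3)C(C)C)cc2)c1`, gives > 26000 nM.
Compound 3, `CCOC(=O)CCCCCOc1cccc(CN(C(=O)c2ccccc2)C(C)C)c1`, gives > 26000 nM.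

Compound 3 thus sits where all three values sit, (the limit of > 26000 nM in this assay, at which 3 of the 3 values shown sit), so none of the three compounds can be ranked against another. The step that the two limits leave unreadable from compound 1 to compound 2 and the step that the two limits leave unreadable from compound 1 to compound 3 each run from one limit to another and reveal neither size nor direction.

The compound awaiting measurement is compound 4, `CCOC(=O)CCCCCOc1cccc(CN(C(=O)c2ccc(-c3cccc(OCC)c3)cc2)C(C)C)c1`. It differs from compound 3 by 3-ethoxyphenyl in place of hydrogen on an aromatic carbon. Among the measured compounds shown here, the nearest precedent is the step from compound 1 to compound 2, which also replaces hydrogen on an aromatic carbon with an aromatic ring, but both ends of that step sit at the limit, so its size cannot be read. With no readable step to draw on, compound 4 is expected to stay at or near the limit as well, which means an expected step that the limit leaves unreadable from compound 3 to compound 4 in this assay. Compound 4 is accordingly estimated at 30000 nM, with a range from 10000 nM to 100000 nM.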

Compound 4, half-maximal effective concentration: > 22300 nM
Compound 4: only a limit was reported; the forecaster's own chance of this, stated with the estimate: 75%; the middle value lies beyond the limit too.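

In this assay compound 4 gives > 22300 nM, which is a limit rather than a number. Among the compounds shown here, compound 3 is also known only as a limit, > 26000 nM, so no step between compound 3 and compound 4 can be read. The compounds shown leave open whether adding 3-ethoxyphenyl changes the reading at all, and in which direction.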